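A few compounds are considered here, and "the series" means these few. Any claim that something is new, unique, unknown or untested is made for them only; others in the source may bear on it.

Compound 1 `COc1cc(CCc2ccc(Cl)c(Cl)c2)cc(OC)c1O`: 20600 nM
Compound 2 `COc1cc(CCc2ccc(F)cc2)cc(OC)c1O`: 10700 nM
Compound 3 `COc1ccc(CCc2ccccc2Cl)cc1OC`: 2040 nM

In a functional assay on MKN-45 cells (Homo sapiens) for antiproliferative activity, read by MTT assay, with a stated time of 72 h (on this read-out higher numbers stand for weaker inhibition and lower numbers for stronger inhibition), compound 2 gives 10700 nM and compound 1, which shares its core, gives 20600 nM, so these two lie within the scatter of each other. Compound 3 gives 2040 nM, a lower number than compound 2 and beyond the scatter. Compound 4 `COc1cc(CCc2ccc([N+](=O)[O-])cc2)cc(OC)c1O` has nitro in place of fluoro on an aromatic carbon, para to a large group (nitro in place of fluoro on an aromatic carbon). Among the compounds with values here, no measured pair differs in one place, so the data offer no direct guide to this change. The expectation is therefore no step beyond the scatter, a modest basis given how little has been measured. The expected change is a 1.2-fold lower number from compound 2 to compound 4 (0.08 log units; within the scatter). For compound 4 the estimated value is 9000 nM, with an expected range from 3000 nM to 25000 nM.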

Compound 4, half-maximal inhibitory concentration: 15400 nM
The estimate for compound 4 lay 1.7-fold (0.23 log units) below the measured number, and the stated range covers the measured number.
By their numbers in this assay, from the lowest: compound 3; then compounds 2, 4 and 1 (each within the scatter of the next).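

In this assay, within the data shown here, nitro in place of fluoro on an aromatic carbon, para to a large group, gives a 1.4-fold higher number from compound 2 to compound 4 (0.16 log units; within the scatter), the first comparison here that differs in one place. It shows that, on the shared core, this position accepts three heavy atoms in place of one, and two added hydrogen-bond acceptors, without a step beyond the scatter. Nothing measured here accounts for this result. As far as these compounds go, whether an amine or a carboxylic acid on this carbon would give a step beyond the scatter remains open.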